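The compounds below may be only part of what the source reports. "The series", "measured", "known", "first", "only" and "open" are said of these compounds alone.

Of the compounds shown here, three built on one shared core have been measured in a functional assay on NCI-H1975 cells (Homo sapiens) for inhibition, read by CellTiter-Glo, with a stated time of 72 h; on this read-out lower numbers stand for stronger inhibition of growth and higher numbers for weaker inhibition of growth. Compound 1 `C=CC(=O)Nc1cc(Nc2ncc(Cl)c(Nc3ccccc3S(=O)(=O)C(C)C)n2)c(OC)cc1N1CCC(N2CCN(C)CC2)CC1` gives 23 nM in this assay. Compound 2 `C=CC(=O)Nc1cc(Nc2ncc(Cl)c(Nc3ccccc3S(=O)(=O)C(C)C)n2)c(OC)cc1N1CCN(S(C)(=O)=O)CC1` gives 40 nM. Compound 3 `C=CC(=O)Nc1cc(Nc2ncc(Cl)c(Nc3ccccc3S(=O)(=O)C(C)C)n2)c(OC)cc1N1CCN(C)CC1` gives 43 nM, which stands highest of the three numbers shown, though its gaps to compound 2 and to compound 1 both lie within the scatter. Going by the values given here, the single one-point step among them, a 1.1-fold higher number from compound 2 to compound 3 (0.03 log units; within the scatter), shows that exchanging the group on the ring nitrogen left the number essentially where it was. Compound 4 `C=CC(=O)Nc1cc(Nc2ncc(Cl)c(Nc3ccccc3S(=O)(=O)C(C)C)n2)c(OC)cc1N1CCN(C(C)C)CC1` is not yet measured; it differs from compound 3 by isopropyl in place of methyl on an amine nitrogen in a ring. The step between compound 2 and compound 3 is the only one that bears on this change, since it also alters the group on the same ring nitrogen, and that step was within the scatter. The step from compound 3 to compound 4 in this assay is therefore expected to be a 1.0-fold higher number from compound 3 to compound 4 (0.02 log units; within the scatter), with no direction claimed beyond the scatter. Compound 4 is estimated at 45 nM, within a range from 20 nM to 100 nM.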

Compound 4, concentration for 50% growth inhibition: 25 nM
For compound 4 the middle estimate is 1.8-fold (0.26 log units) above the measured one, within the range that was stated.
By their numbers in this assay, from the lowest: compounds 1, 4, 2 and 3 (each within the scatter of the next).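

In this assay, isopropyl in place of methyl on the amine nitrogen in the ring gives a 1.7-fold lower number from compound 3 to compound 4 (0.24 log units; within the scatter) and so adds a carbon-branched group to what this position has been seen to carry. Set against the methylsulfonyl group, the same isopropyl gives a 1.6-fold lower number from compound 2 to compound 4 (0.20 log units; within the scatter), so methyl, methylsulfonyl and isopropyl at this nitrogen now all stand within the scatter of one another, a statement that covers only these three groups. Nothing shown gives a reason for these numbers.

The compounds shown leave open whether a group of another kind on this nitrogen, such as a carboxylic acid, a hydroxyethyl chain or a cyclopropyl ring, would also stay within the scatter. They also leave open whether the isopropyl for methyl exchange would read the same on a different core.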